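The source may report more compounds than this note shows. Statements on the series, on what has been measured and on what is new or still open speak of the compounds shown alone.

Measured compounds:
Compound 1, `COc1cccc(S(=O)(=O)NC2=NCCN2C(=S)SN2CCn3c2nsc3=S)c1`, in a functional assay on KYSE-510 cells (Homo sapiens) for antiproliferative activity, read by crystal violet staining, with a stated time of 96 h (on this read-out lower numbers stand for stronger inhibition of growth and higher numbers for weaker inhibition of growth), gives only a limit, >= 20000 nM.
Compound 2, `COc1ccc(OC)c(S(=O)(=O)NC2=NCCN2C(=S)SN2CCn3c2nsc3=S)c1`, in this assay gives only a limit, >= 20000 nM.
Compound 3, `O=S(=O)(NC1=NCCN1C(=S)SN1CCn2c1nsc2=S)c1ccc(Cl)cc1Cl`, in this assay gives only a limit, >= 20000 nM.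

Compound 2 therefore stands at a limit, and the two other values shown stand at the same limit; all three sit at the limit of >= 20000 nM in this assay, at which 3 of the 3 values shown sit, so no order among them can be read. The steps a step that the two limits leave unreadable from compound 1 to compound 2, a step that the two limits leave unreadable from compound 1 to compound 3 and a step that the two limits leave unreadable from compound 2 to compound 3 are unreadable for that reason. Compound 4, `O=S(=O)(NC1=NCCN1C(=S)SN1CCn2c1nsc2=S)c1cc(Cl)cc(Cl)c1`, differs from compound 2 by 3,5-dichlorophenyl in place of 2,5-dimethoxyphenyl on a sulfonyl sulfur. The measured steps that bear on this change all run between limits and give no size, so no step beyond the scatter can be foreseen in either direction. Compound 3, which also carries a dichlorophenyl group, shows in this assay only the limit >= 20000 nM. The step of a number no higher from compound 2 to compound 4 (the limit leaves the size open) is thus expected to be flat. Compound 4 is expected to give a limit as well, estimated at 20000 nM with a range from 10000 nM to 60000 nM.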

Compound 4, concentration for 50% growth inhibition: >= 20000 nM
Compound 4: no number, only a limit; the forecaster's own chance of this, stated with the estimate: 85%; the middle value sits exactly at the limit.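

The steps from compound 4 to compound 1, compound 2 and compound 3 cannot be read, as all four compounds share one limit: the limit of >= 20000 nM in this assay, at which 4 of the 4 values shown sit.

The compounds shown leave open how strongly any of them inhibits growth and whether the group on the sulfonyl sulfur affects that inhibition.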